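The compounds below may be only part of what the source reports. "The series", "measured", "known", "first", "only" and "open" are said of these compounds alone.

Compound 1, with structure `COc1cc(/C=C/C(=O)/C=C/c2cc(OC)c(OC)c(OC)c2)ccc1OCc1cn(CCCOc2cc(=O)oc3ccccc23)nn1`, is one of two measured compounds. In a functional assay on PC-3 cells (Homo sapiens) for inhibition, read by sulforhodamine B assay, with a stated time of 48 h, tested at 50 uM (a higher number here means more inhibition of growth at the concentration tested, a lower number less inhibition of growth), compound 1 gives 12%. Compound 2, with structure `COc1ccc(/C=C/C(=O)/C=C/c2ccc(OCc3cn(CCOc4cc(=O)oc5ccccc45)nn3)c(OC)c2)cc1OC`, gives 19% in this assay; the two numbers lie within the usual scatter of each other, so neither stands apart. Compound 3, with structure `COc1cccc(/C=C/C(=O)/C=C/c2ccc(OCc3cn(CCCOc4cc(=O)oc5ccccc45)nn3)c(OC)c2)c1`, is not yet measured. Its change from compound 1 is 3-methoxyphenyl in place of 3,4,5-trimethoxyphenyl on a double-bonded chain carbon bound to a double-bonded chain carbon. Among the compounds with values here, no measured step of this kind is available, so no step beyond the scatter is expected. Compound 3 is expected to give 12%, between 2% and 26%, a step of no change at the digits printed from compound 1 to compound 3 (within the scatter).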

Compound 3, percent growth inhibition at one concentration: "not active" (no number reported)
Compound 3: no number reported; there is nothing to compare the estimate with.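

Within the data shown here, compound 3 is reported as "not active" without a number, so no step from compound 1 to compound 3 can be read. As far as these compounds go, how swapping 3,4,5-trimethoxyphenyl for 3-methoxyphenyl affects growth inhibition stays open. No further data bear on this result.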